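This account rests on a few compounds, and the source may have more. Where it says the series, first, only, none or still open, it means among the compounds named here.

Measured compounds:
compound 1, `COc1ccc2c(c1)c(/C=N\NC(=O)c1c[nH]c3ccc(Br)cc13)cn2Cc1ccc(Cl)cc1` — > 100000 nM (a limit, not a number)
compound 2, `O=C(N/N=C\c1cn(Cc2ccc(Cl)cc2)c2ccc(Br)cc12)c1c[nH]c2ccccc12` — 3700 nM
compound 3, `COc1ccc(Cn2cc(/C=N\NC(=O)c3cn(C)c4ccccc34)c3ccc(F)cc32)cc1` — 9600 nM

In a functional assay on LNCaP cells (Homo sapiens) for cytotoxicity (on this read-out lower numbers stand for stronger inhibition and higher numbers for weaker inhibition), compound 2 gives 3700 nM. Compound 3 gives 9600 nM, a higher number, and the gap lies beyond the scatter. For compound 1 the result is only a limit, > 100000 nM, which is the limit of > 100000 nM in this assay, at which 1 of the 3 values shown sits, and yields no number. Of the two numbers shown, compound 2 stands lowest.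

Compound 4, `O=C(N/N=C\c1cn(Cc2ccc(Cl)cc2)c2ccccc12)c1c[nH]c2ccccc12`, differs from compound 2 in one place: hydrogen in place of bromo on an aromatic carbon. Among the measured compounds shown here, no pair of measured compounds shows this change on its own, so the expectation rests on compound 2 alone. The step is expected to be a modest one toward weaker inhibition, a 1.8-fold higher number from compound 2 to compound 4 (0.24 log units; within the scatter), and a result within the scatter would not be surprising. Compound 4 is estimated at 6500 nM, with a range from 2500 nM to 17000 nM.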

Compound 4, half-maximal inhibitory concentration: > 100000 nM
Compound 4: only a limit was reported (the forecaster's own chance of this, stated with the estimate: 8%); at least 15-fold (1.18 log units) between middle value and limit.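

Hydrogen in place of bromo on this aromatic carbon, meta to a fused ring and para to a fused ring, gives an at least 27-fold higher number from compound 2 to compound 4 (1.43 log units; beyond the scatter), the only single-place step shown in the series. In this assay, among the compounds shown here, this pair shows that the bromo separates a measurable value from no measurable value, which the earlier compounds, differing in several places, could not show. Compound 4 gives only a limit, so the step is a lower bound and its full size stays unknown: the limit of > 100000 nM in this assay, at which 2 of the 4 values shown sit.

From the compounds shown here alone, only bromo and hydrogen can be compared at this carbon, so it remains open how a nitrile or an amine there would read out. Going by these compounds, with a single pair, it is also open whether the bromo matters to the same degree when other groups on the core change.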